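Carbamoyl to 4-Fluorophenyl Among Compounds Read Only as Limits

The source may hold more compounds than are shown below. What is called first, only, known or untested is meant among the compounds shown, and "the series" means these compounds.

In an ADME assay on HEK293 cells (Homo sapiens) for cytotoxicity, with a stated time of 72 h (a higher number here means that more compound is needed for the effect, a lower number that less compound is needed), compound 3 (`C=C[C@@](C)(/C=C/c1ccc(O)c(/C=C/C(N)=O)c1)CCC=C(C)C`) gives > 36600 nM which is a limit and not a number. Compound 2 (`C=C[C@@](C)(/C=C/c1ccc(O)c(/C=C/C#N)c1)CCC=C(C)C`) gives > 36600 nM which is also a limit. Compound 1 (`C=C[C@@](C)(/C=C/c1ccc(O)c(/C=C/C(=O)c2ccccc2)c1)CCC=C(C)C`) gives > 7410 nM which is a limit as well. Compound 4 (`C=C[C@@](C)(/C=C/c1ccc(O)c(/C=C/c2ccc(F)cc2)c1)CCC=C(C)C`) carries 4-fluorophenyl in place of carbamoyl on a double-bonded chain carbon bound to a double-bonded chain carbon. The measured steps bearing on this change are a step that the two limits leave unreadable from compound 2 to compound 3 and a step that the two limits leave unreadable from compound 1 to compound 3 and neither offers a size to carry over. With only limits to go on, the expected change is modest and its direction uncertain (an at least 1.8-fold lower number from compound 3 to compound 4 (0.26 log units; that floor lies within the scatter)). Compound 4 is expected at 20000 nM with an estimated range from 7000 nM to 45000 nM and may again return only a limit.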

Compound 4, half-maximal effective concentration: > 36600 nM
Compound 4 gave a limit, no number; the forecaster's own chance of this, stated with the estimate: 75%; middle value at least 1.8-fold (0.26 log units) from the limit.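

Among these compounds, compound 4, like compound 1, compound 2 and compound 3, gave only a limit, so no step among them can be read. The compounds shown leave open what concentration any of them actually needs for the effect.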